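Series notes: thioether variation and cytotoxicity, compound 4 pending

A few compounds are considered here, and "the series" means these few. Any claim that something is new, unique, unknown or untested is made for them only; others in the source may bear on it.

Measured compounds:
Compound 1 `Cc1nnc(SCc2ccccc2Cl)n1N1C(=O)c2ccccc2C1=O`; in a functional assay on PC-3M cells (Homo sapiens) for cytotoxicity, read by MTT assay, with a stated time of 48 h (a higher number here means a weaker inhibitor, a lower number a stronger inhibitor), compound 1 gives > 200000 nM, a limit of the assay.
Compound 2 `CCCc1nnc(SCc2ccccc2Cl)n1N1C(=O)c2ccccc2C1=O`; in this assay compound 2 gives > 200000 nM, a limit of the assay.
Compound 3 `COc1cc(-c2nnc(SCc3ccccc3Cl)n2N2C(=O)c3ccccc3C2=O)cc(OC)c1OC`; in this assay compound 3 gives > 200000 nM, a limit of the assay.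

Compound 3 therefore stands only at a limit, as do the other two (the limit of > 200000 nM in this assay, at which 3 of the 3 values shown sit). The steps a step that the two limits leave unreadable from compound 1 to compound 3 and a step that the two limits leave unreadable from compound 2 to compound 3 are unreadable, as is a step that the two limits leave unreadable from compound 1 to compound 2.

Compound 4 `COc1ccc(C(=O)CSc2nnc(-c3cc(OC)c(OC)c(OC)c3)n2N2C(=O)c3ccccc3C2=O)cc1` differs from compound 3 by (4-methoxyphenyl)carbonyl in place of 2-chlorophenyl on a saturated chain carbon bound to a sulfur. No measured step bears on this change, so nothing shown points to a readable shift in this assay. The step expected is a number no higher from compound 3 to compound 4 (the limit leaves the size open). Compound 4 is expected near 200000 nM, within 40000 nM to 1000000 nM.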

Compound 4, half-maximal inhibitory concentration: 32800 nM
Compound 4: the middle estimate sits 6.1-fold (0.79 log units) above what was measured, outside the stated range (below it).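

In this assay, within the data shown here, (4-methoxyphenyl)carbonyl in place of 2-chlorophenyl on a saturated chain carbon bound to a sulfur gives an at least 6.0-fold lower number from compound 3 to compound 4 (0.78 log units; beyond the scatter) and is the first readable step. The earlier steps shown here cannot be read, and compound 4 alone has a value that is not a limit: the limit of > 200000 nM in this assay, at which 3 of the 4 values shown sit.

From the compounds shown here alone, it remains open whether the carbonyl or the methoxy of the entering group carries this step. Going by these compounds, an amine in place of that methoxy, and the same change with propyl in place of 3,4,5-trimethoxyphenyl, also remain open.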